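A few compounds are considered here, and "the series" means these few. Any claim that something is new, unique, unknown or untested is made for them only; others in the source may bear on it.

Working notes on the series. Compound 1 `c1ccc(NN=C(c2nc3ccccc3[nH]2)c2nc3ccccc3[nH]2)cc1` gives 83200 nM in a functional assay on MCF7 cells (Homo sapiens) for cytotoxicity, read by MTT assay, with a stated time of 72 h (on this read-out lower numbers stand for stronger inhibition and higher numbers for weaker inhibition), compound 2 `Cc1ccc(NN=C(c2nc3ccccc3[nH]2)c2nc3ccccc3[nH]2)cc1` gives 95800 nM, and compound 3 `COc1ccc(NN=C(c2nc3ccccc3[nH]2)c2nc3ccccc3[nH]2)cc1` gives 215000 nM, the highest of the three numbers. The measured steps at this aromatic carbon are a 1.2-fold higher number from compound 1 to compound 2 (0.06 log units; within the scatter), a 2.6-fold higher number from compound 1 to compound 3 (0.41 log units; beyond the scatter) and a 2.2-fold higher number from compound 2 to compound 3 (0.35 log units; beyond the scatter). Compound 4 `Clc1ccc(NN=C(c2nc3ccccc3[nH]2)c2nc3ccccc3[nH]2)cc1` carries chloro in place of methoxy on an aromatic carbon. Within the data shown here, no measured step exchanges methoxy for chloro, so the only guidance is that changes at this carbon have so far stayed modest or within the scatter. The expectation for compound 4 in this assay is therefore a small step, if any, back toward the numbers of compound 1 and compound 2, that is a 2.0-fold lower number from compound 3 to compound 4 (0.29 log units; within the scatter). Compound 4 is estimated at 110000 nM, with a range from 45000 nM to 270000 nM.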

Compound 4, half-maximal inhibitory concentration: 140000 nM
Beside the measured number, compound 4's estimate is 1.3-fold (0.10 log units) below it, within the range that was stated.
By their numbers in this assay, from the lowest: compounds 1, 2, 4 and 3 (each within the scatter of the next, the first and the last beyond it).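

In this assay, among these compounds, chloro, on an aromatic carbon para to a large group, gives the first compound in the set that is separated from none of the others: a 1.5-fold lower number from compound 3 to compound 4 (0.19 log units; within the scatter), a 1.5-fold higher number from compound 2 to compound 4 (0.16 log units; within the scatter), and a 1.7-fold higher number from compound 1 to compound 4 (0.23 log units; within the scatter). Among the compounds shown here, compound 3 thus remains the only compound with steps beyond the scatter, and chloro adds no such step at this carbon. No available evidence bears on the reason for this result. On these data alone, whether an amine or a carboxylic acid at this carbon would stay within the same band remains open.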